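From Benzimidazolyl to Indolyl on the Ring Nitrogen Arm

The source may report more compounds than this note shows. Statements on the series, on what has been measured and on what is new or still open speak of the compounds shown alone.

Compound 1 `CNC(=O)c1cc(C(=O)NC2CC2)cn(Cc2cccc(OC)c2)c1=O` 3
Compound 2 `CNC(=O)c1cc(C(=O)NC2CC2)cn(CC2CCCOC2)c1=O` 2
Compound 3 `CNC(=O)c1cc(C(=O)NC2CC2)cn(Cc2ccc3nc[nH]c3c2)c1=O` 1.2

In a physicochemical assay for lipophilicity, at pH 7.4 (a lower number here means a more polar compound, a higher number a more lipophilic compound), compound 3 stands lowest of the three measured compounds, with compound 2 nearest and compound 1 furthest. Compound 4 `CNC(=O)c1cc(C(=O)NC2CC2)cn(Cc2cccc3cc[nH]c23)c1=O` differs from compound 3 by one change: 1H-indol-7-yl in place of 1H-benzimidazol-6-yl on a saturated chain carbon bound to an aromatic nitrogen. Among the measured compounds shown here, no measured step contains 1H-indol-7-yl, so the guide is indirect. The steps of a number 1.80 log units lower from compound 1 to compound 3 (beyond the scatter) and a number 0.80 log units lower from compound 2 to compound 3 (beyond the scatter) both ran downward when 1H-benzimidazol-6-yl entered, the larger from 3-methoxyphenyl, the smaller from oxan-3-yl. Removing that group again is therefore expected to move this assay upward, though probably not all the way back to compound 1. For compound 4 the expected value is 2.4, within 1.9 to 2.9. The step from compound 3 is estimated at a number 1.20 log units higher from compound 3 to compound 4 (beyond the scatter).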

Compound 4, distribution coefficient: 3.7
For compound 4 the middle estimate is 1.30 log units below the measured one, and the stated range ends below it.
By their numbers in this assay, from the lowest: compound 3; then compound 2; then compound 1; then compound 4.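

In this assay, the place on a saturated chain carbon bound to an aromatic nitrogen reaches beyond what 3-methoxyphenyl gave: 1H-indol-7-yl stands above it (a number 0.70 log units higher from compound 1 to compound 4 (beyond the scatter)) and above oxan-3-yl (a number 1.70 log units higher from compound 2 to compound 4 (beyond the scatter)). Between two groups of equal heavy-atom count, 1H-indol-7-yl in place of 1H-benzimidazol-6-yl gives the largest step seen so far (a number 2.50 log units higher from compound 3 to compound 4 (beyond the scatter)). Nothing available accounts for the size of this step.

The change alters both the ring atoms and the point of attachment, and the compounds shown do not separate the two. That leaves open where 1H-indol-6-yl on the same carbon would fall.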